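This account rests on a few compounds, and the source may have more. Where it says the series, first, only, none or still open, it means among the compounds named here.

Working notes on the series, read in an ADME assay on J774 cells (Mus musculus) for cytotoxicity; a higher number here means that more compound is needed for the effect, a lower number that less compound is needed. Compound 1 `CCCCCCC/C=C/c1c(C)[nH]c2ccccc2c1=O` gives 28000 nM. Compound 2 `Cc1[nH]c2ccccc2c(=O)c1/C=C/C(=O)OC(C)(C)C` is recorded only as a limit, > 40000 nM. Compound 3 `Cc1[nH]c2ccccc2c(=O)c1/C=C/c1ccccc1` is likewise recorded only as a limit, > 36300 nM, so it has no exact number.

Compound 4 `Cc1[nH]c2ccccc2c(=O)c1/C=C/c1ccc(O)cc1` carries one change from compound 3: hydroxy in place of hydrogen on an aromatic carbon, para to a large group (hydroxy in place of hydrogen on an aromatic carbon).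

For the measured compounds named here, no measured step makes this change. The nearest evidence comes from exchanges of the group on the double-bonded chain carbon. These give an at least 1.2-fold higher number from compound 1 to compound 3 (0.11 log units; that floor lies within the scatter) and an at least 1.4-fold higher number from compound 1 to compound 2 (0.15 log units; that floor lies within the scatter), while the remaining pair gives a step that the two limits leave unreadable from compound 2 to compound 3. Going by the values given here, with these steps as the only guide, and with an at least 1.2-fold higher number from compound 1 to compound 3 (0.11 log units; that floor lies within the scatter) as the closest, no step beyond the scatter is expected in this assay, and no direction can be assigned with confidence. A further limit is a likely outcome for compound 4.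

The estimate means an expected step that the limit leaves unreadable from compound 3 to compound 4.

The expected value for compound 4 is 40000 nM, with an estimated range of 20000 nM to 80000 nM.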

Compound 4, half-maximal effective concentration: > 36100 nM
Compound 4 gave a limit, no number; the forecaster's own chance of this, stated with the estimate: 65%; the middle value is on the limit's open side.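

In this assay compound 4 is recorded only as a limit, > 36100 nM, so hydroxy in place of hydrogen on the aromatic carbon, para to a large group, does not yield an exact number. The steps to compound 4 from compound 3 and from compound 2 cannot be read. For the compounds shown here, the one readable step gives an at least 1.2-fold higher number from compound 1 to compound 4 (0.11 log units; that floor lies within the scatter), so the 4-hydroxyphenyl group, like phenyl, shows no step beyond the scatter when it takes the place of heptyl.

Whether hydroxy moves the number at all in this assay stays open, since compound 1 alone has an exact value among the compounds shown. Also open, from the compounds shown here alone, is what an amine or a carboxylic acid in place of this hydroxy would give.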